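The compounds below may be only part of what the source reports. "The series", "measured", "known", "first", "only" and "open" are said of these compounds alone.

The measured compounds:
Compound 1, `O=C(CCC(=O)c1ccc(F)cc1)NCCCO`: in a functional assay on the whole organism with Mus musculus as the target (on this read-out lower numbers stand for an effect already at smaller amounts and higher numbers for an effect only at larger amounts of compound), compound 1 reaches only the limit > 400 mg/kg.
Compound 2, `COc1ccc(C(=O)CCC(=O)NCCCO)cc1`: in this assay compound 2 reaches only the limit > 600 mg/kg.

Compound 2 thus stands at a limit of this assay, not at a number. Within the data shown here, compound 1 stands at a limit as well, so the one measured step, a step that the two limits leave unreadable from compound 1 to compound 2, has no readable size because the limit of > 400 mg/kg in this assay, at which 1 of the 2 values shown sits, and the limit of > 600 mg/kg in this assay, at which 1 of the 2 values shown sits, mark its two ends. Compound 3, `Cc1ccc(C(=O)CCC(=O)NCCCO)cc1`, differs from compound 2 by methyl in place of methoxy on an aromatic carbon. With both neighbours at limits and no readable step in hand, no step beyond the scatter in this assay can be expected from this change in either direction, and a further limit rather than a number is the likely outcome. Compound 3 is therefore estimated at 600 mg/kg, with a range from 200 mg/kg to 2000 mg/kg. This corresponds to an expected step of a number no higher from compound 2 to compound 3 (the limit leaves the size open).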

Compound 3, dose for half-maximal effect: > 300 mg/kg
Compound 3 gave a limit, no number; the forecaster's own chance of this, stated with the estimate: 80%; the middle value lies beyond the limit too.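

Among these compounds, compound 1, compound 2 and compound 3 all stand at limits in this assay, not at numbers, so no step among them can be read. The compounds shown leave open whether fluoro, methoxy or methyl on the aromatic carbon makes any difference to the read-out.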